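This account rests on a few compounds, and the source may have more. Where it says the series, first, only, none or still open, it means among the compounds named here.

Working notes on the series. In a functional assay on Gurav cells (Homo sapiens) for inhibition, read by sulforhodamine B assay (a higher number here means a weaker inhibitor of growth, a lower number a stronger inhibitor of growth), compound 1 (`Cc1ccc2[nH]c(-c3ccc(-c4ccc(-c5cccc(Cl)c5)cc4)cc3)nc2c1`) gives 2120 nM, and compound 2 (`Cc1ccc2[nH]c(-c3ccc(-c4ccc(-c5ccccc5)cc4)cc3)nc2c1`) gives 3310 nM. Among the measured compounds shown here, compound 2 therefore stands within the scatter of the only other measured number, and the series has no clear order so far.

Compound 3 (`Cc1ccc2[nH]c(-c3ccc(-c4ccc(-c5ccc(O)cc5)cc4)cc3)nc2c1`) differs from compound 2 by one change, phenyl to 4-hydroxyphenyl: hydroxy in place of hydrogen on an aromatic carbon. This places hydroxy in place of hydrogen on an aromatic carbon, para to a large group.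

For the measured compounds named here, only one measured step bears on this change: hydrogen in place of chloro on an aromatic carbon, a 1.6-fold higher number from compound 1 to compound 2 (0.19 log units; within the scatter). Going by the values given here, that step stays within the scatter, but it is only indirect evidence, since no measured compound carries a hydroxy group. The data therefore favour no direction, and the range has to stay wide. In this assay, no step beyond the scatter is expected, and the estimate is a 1.2-fold lower number from compound 2 to compound 3 (0.07 log units; within the scatter). For compound 3, the expected value is 2800 nM, with an estimated range of 900 nM to 8000 nM.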

Compound 3, concentration for 50% growth inhibition: 11300 nM
The estimate for compound 3 lay 4.0-fold (0.61 log units) below the measured number, and the stated range ends below it.
By their numbers in this assay, from the lowest: compounds 1 and 2 (each within the scatter of the next); then compound 3.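

Notes on the result. In this assay, among the compounds shown here, hydroxy in place of hydrogen on an aromatic carbon, para to a large group, gives a 3.4-fold higher number from compound 2 to compound 3 (0.53 log units; beyond the scatter) and is the first single change to move beyond the scatter, with compound 3 the weaker inhibitor of growth. Set against the chloro-bearing compound, 4-hydroxyphenyl in place of 3-chlorophenyl gives a 5.3-fold higher number from compound 1 to compound 3 (0.73 log units; beyond the scatter) in the same direction, so compound 3 stands apart from compounds 1 and 2, and the outer aryl ring proves not to be indifferent to substitution, which the chloro step alone could not show. The data shown offer no measurement that accounts for this step.

As far as these compounds go, whether the weakening belongs to the hydroxy group itself or to any added group at this carbon remains open, and a methoxy group, an amine or a carboxylic acid in the same place would separate these readings. Also open, from the compounds shown here alone, is how hydroxy would read on the carbon that holds chloro in compound 1.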